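Methyl at the phenyl ring of the pyrazinone amide series

This account rests on a few compounds, and the source may have more. Where it says the series, first, only, none or still open, it means among the compounds named here.

Compound 1 `COc1cccc(Cc2cc(-c3ccccc3)nn(CC(=O)Nc3ccc(Br)cc3)c2=O)c1`: in an assay on HL-60 cells for agonist activity at N-formyl peptide receptor 3 (Homo sapiens), read by calcium flux (on this read-out higher numbers stand for an effect only at larger amounts of compound and lower numbers for an effect already at smaller amounts), compound 1 gives only a limit, > 50000 nM.
Compound 2 `COc1cccc(Cc2cc(-c3ccccc3)nn(CC(=O)Nc3ccc(F)cc3)c2=O)c1`: in this assay compound 2 likewise gives only a limit, > 50000 nM.

Compound 2 therefore stands at the limit, not at a number; the step that the two limits leave unreadable from compound 1 to compound 2 is unreadable because both values sit at the limit of > 50000 nM in this assay, at which 2 of the 2 values shown sit. Compound 3 `COc1cccc(Cc2cc(-c3ccc(C)cc3)nn(CC(=O)Nc3ccc(F)cc3)c2=O)c1` differs from compound 2 by methyl in place of hydrogen on an aromatic carbon. Among the compounds with values here, no measured step bears on this change, so no step beyond the scatter is expected, and a step that the limit leaves unreadable from compound 2 to compound 3 is the estimated step. Compound 3 is expected to give about 60000 nM in this assay, within 10000 nM to 300000 nM.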

Compound 3, half-maximal effective concentration: > 50000 nM
Compound 3 ended at the assay's limit (the forecaster's own chance of this, stated with the estimate: 80%); the middle value does not contradict the limit.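

No step can be read from compound 2 to compound 3, nor from compound 1 to compound 2, because every value is a limit: the limit of > 50000 nM in this assay, at which 3 of the 3 values shown sit.

The compounds shown leave open whether the fluoro or methyl change has any effect in this assay.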